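Swapping Chloro for Methoxy: An Expectation for Compound 4

This account rests on a few compounds, and the source may have more. Where it says the series, first, only, none or still open, it means among the compounds named here.

Compound 1, `CCn1cc(-c2ccc(Cl)cc2)c(=O)c2cc(F)c(N3CCNCC3)cc21`, gives 15400 nM in a functional assay on HeLa cells (Homo sapiens) for antiproliferative activity, read by MTT assay, with a stated time of 48 h; on this read-out lower numbers stand for stronger inhibition and higher numbers for weaker inhibition.
Compound 2, `CCn1cc(-c2ccc(OC)cc2)c(=O)c2cc(F)c(N3CCNCC3)cc21`, gives 69000 nM.
Compound 3, `CN1CCN(c2cc3c(cc2F)c(=O)c(-c2cccc(Cl)c2)cn3C2CC2)CC1`, gives 15800 nM.

Compound 2 differs from compound 1 by methoxy in place of chloro on an aromatic carbon, and this made a 4.5-fold higher number from compound 1 to compound 2 (0.65 log units; beyond the scatter). Compound 4, `COc1cccc(-c2cn(C3CC3)c3cc(N4CCN(C)CC4)c(F)cc3c2=O)c1`, is not yet measured; it differs from compound 3 by methoxy in place of chloro on an aromatic carbon. The surroundings are not identical: in the first pair the change sits para to a large group, in the second meta to a large group, so it is the same kind of change, not the same. How the cores of compound 1 and compound 3 differ is not broken down here; their values lie within the scatter of each other. Among the measured compounds shown here, from compound 3 to compound 4 a step of about a 3.8-fold higher number from compound 3 to compound 4 (0.58 log units; beyond the scatter) is expected in this assay, resting on the single earlier step of a 4.5-fold higher number from compound 1 to compound 2 (0.65 log units; beyond the scatter). Compound 4 is therefore estimated at 60000 nM, between 25000 nM and 150000 nM.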

Compound 4, half-maximal inhibitory concentration: 14800 nM
Estimate against measurement, compound 4: 4.1-fold (0.61 log units) above; the whole stated range lies above it.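

In this assay, putting methoxy in place of chloro gives a 1.1-fold lower number from compound 3 to compound 4 (0.03 log units; within the scatter), a step that leaves the two compounds indistinguishable on this read-out. The same swap therefore does not carry over unchanged from one core to the other: the same change on two cores in this assay, a 4.5-fold higher number (0.65 log units; beyond the scatter) from compound 1 to compound 2 and a 1.1-fold lower number (0.03 log units; within the scatter) from compound 3 to compound 4, 4.8-fold (0.68 log units) apart, beyond the scatter of two such steps. Among the compounds shown here, only one pair stands on each core, and the pairs differ both in the core and in where the group sits; the data do not show which of these differences matters, or how the swap would behave on a further core.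

As far as these compounds go, it remains open how an amine or a hydroxy group on the same aromatic carbon of compound 3 would compare with chloro and methoxy. A longer chain, such as ethoxy, is open as well.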